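Hydroxymethyl on the Ether Chain and Serum Free Fraction

The compounds below may be only part of what the source reports. "The series", "measured", "known", "first", "only" and "open" are said of these compounds alone.

Measured compounds:
- compound 1, `COc1ccccc1C1C(C(=O)C(C)(C)C)=C(O)C(=O)N1c1ccc(-c2ccon2)cc1`, gives 0.002
- compound 2, `CC(C)(C)C(=O)C1=C(O)C(=O)N(c2ccc(-c3ccon3)cc2)C1c1ccccc1OCCO`, gives 0.012
- compound 3, `COc1ccccc1C1C(C(=O)C(C)C)=C(O)C(=O)N1c1ccc(-c2ccsc2)cc1`, gives 0.001

These three were tested in an ADME assay on the whole organism (serum, Rattus norvegicus) for protein binding; a higher number here means a larger unbound share of the compound, a lower number a smaller unbound share. Compound 2 differs from compound 1 by one change, (hydroxymethyl in place of hydrogen on a saturated chain carbon bound to an oxygen on an aromatic ring), and that change brought a 6.0-fold higher number from compound 1 to compound 2 (0.78 log units; beyond the scatter). Compound 3 has a core that differs from that of compound 1 in more than one place, and the difference between the two cores is not broken down here; in this assay compound 3 gives the lowest of the three numbers, though its gap to compound 1 lies within the usual scatter, while compound 2 stands well above it.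

Compound 4, `CC(C)C(=O)C1=C(O)C(=O)N(c2ccc(-c3ccsc3)cc2)C1c1ccccc1OCCO`, is not yet measured. Among the measured compounds shown here, it differs from compound 3 by hydroxymethyl in place of hydrogen on a saturated chain carbon bound to an oxygen on an aromatic ring, which is the same change as the one from compound 1 to compound 2, made at the same place. Compound 4 is therefore expected to show a step of a 6.0-fold higher number from compound 3 to compound 4 (0.78 log units; beyond the scatter), resting on the earlier 6.0-fold higher number from compound 1 to compound 2 (0.78 log units; beyond the scatter) applied to the value of compound 3, 0.001. The estimate for compound 4 is 0.006, expected to fall between 0.002 and 0.015.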

Compound 4, unbound fraction: 0.002
Estimate against measurement, compound 4: 3.0-fold (0.48 log units) above, and the stated range covers the measured number.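

On the second core, the same swap of methoxy for 2-hydroxyethoxy gives a 2.0-fold higher number from compound 3 to compound 4 (0.30 log units; within the scatter) in this assay, a step that cannot be told apart from repeat-measurement noise, whereas the step on the core of compound 1 stood clear of it. The size of this step therefore did not carry from one core to the other, and the two steps differ by more than the scatter allows: the same change on two cores in this assay, a 6.0-fold higher number (0.78 log units; beyond the scatter) from compound 1 to compound 2 and a 2.0-fold higher number (0.30 log units; within the scatter) from compound 3 to compound 4, 3.0-fold (0.48 log units) apart, beyond the scatter of two such steps

Among the compounds shown here, this rests on only two pairs of compounds, so it does not show which of the several differences between the two cores matters, nor how the change would behave on a further core. It also gives no reason for the gap between the steps.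

Still open, going by these compounds, is whether a longer chain ending in a hydroxyl, or an amine or a carboxylic acid, in place of the 2-hydroxyethoxy group, would give a clear step on both cores. Also open, on these data alone, is whether any such step would keep the same size from one core to the other.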